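Propyl to isopropyl on the shared core: working notes

A few compounds are considered here, and "the series" means these few. Any claim that something is new, unique, unknown or untested is made for them only; others in the source may bear on it.

Measured so far in an in vitro assay on U2OS cells for agonist activity at neurotensin receptor type 2 (Homo sapiens), read by reporter gene assay and beta-arrestin recruitment; a higher number here means that more compound is needed for the effect, a lower number that less compound is needed:
compound 1, `COc1cc2nc(C)nc(N3CCN(c4ccccc4OC)CC3)c2cc1OC`, only a limit, > 80000 nM
compound 2, `CCCc1nc(N2CCN(c3ccccc3OC)CC2)c2cc(OC)c(OC)cc2n1`, only a limit, > 80000 nM

Among the compounds with values here, compound 2 stands at a limit in this assay, and the one further value shown is a limit as well. The step that the two limits leave unreadable from compound 1 to compound 2 is accordingly unreadable in size, because both ends sit at the limit of > 80000 nM in this assay, at which 2 of the 2 values shown sit.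

Compound 3, `COc1cc2nc(C(C)C)nc(N3CCN(c4ccccc4OC)CC3)c2cc1OC`, differs from compound 2 by isopropyl in place of propyl on an aromatic carbon. Within the data shown here, the only measured step bears on this change merely as a pair of limits, so its size gives no guide, and no direction can be read from it. With nothing beyond limits in hand, compound 3 is expected to remain at the limit of this assay as well. The expected step that the limit leaves unreadable from compound 2 to compound 3 is thus estimated as none beyond the scatter. For compound 3 the estimated value is 120000 nM, with a range from 30000 nM to 500000 nM.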

Compound 3, half-maximal effective concentration: > 80000 nM
Compound 3: a limit, no number; the forecaster's own chance of this, stated with the estimate: 85%; the middle value does not contradict the limit.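

Within the data shown here, compound 3 also gives only a limit in this assay, so no step from compound 1 or compound 2 to compound 3 can be read: the limit of > 80000 nM in this assay, at which 3 of the 3 values shown sit. The compounds shown leave open whether any group on that aromatic carbon of the shared core gives a measurable value in this assay.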